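Swapping the aryl group on a sulfonamide nitrogen

A few compounds are considered here, and "the series" means these few. Any claim that something is new, unique, unknown or untested is made for them only; others in the source may bear on it.

Measured so far:
compound 1 `COc1ccc(NS(=O)(=O)c2ccc(NC(=O)c3ccc(Cl)cc3Cl)cc2)cc1`: "not determined" (no result reported)
compound 2 `O=C(Nc1ccc(S(=O)(=O)Nc2ccccc2)cc1)c1ccc(Br)cc1F`: 67%
compound 3 `O=C(Nc1ccc(Cl)cc1Cl)c1ccc(S(=O)(=O)Nc2ccccc2)cc1`: "not determined" (no result reported)

Compound 1 stands without a number in a functional assay on HEK293 cells for agonist activity at probable G-protein coupled receptor 27 (Homo sapiens), read by a luciferase reporter and beta-arrestin recruitment, with a stated time of 10 min; a higher number here means a larger maximal response, a lower number a smaller maximal response; no result is reported for it, and the same holds for compound 3. Only compound 2 carries a value, giving 67% in this assay. Compound 4 `Cc1ccccc1NS(=O)(=O)c1ccc(NC(=O)c2ccc(Cl)cc2Cl)cc1` differs from compound 1 in one place: 2-methylphenyl in place of 4-methoxyphenyl on a sulfonamide nitrogen. For the measured compounds named here, no step between two measured compounds is known, so nothing shows how such a change moves the maximal response, and no direction can be read from the data. Going by the values given here, the expectation for compound 4 therefore rests on the single value of compound 2 alone. Compound 4 is expected to give about 50% in this assay, with a wide range from 10% to 90%.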

Compound 4, largest response reached (Emax), in percent of the reference or control that the assay uses: 32%
Estimate against measurement, compound 4: 18 percentage points above; measured number inside the range.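

For the compounds shown here, compound 1 has no number in this assay and compound 4 gives 32% there, so no step between them can be read. The compounds shown leave open how swapping 4-methoxyphenyl for 2-methylphenyl on a sulfonamide nitrogen moves the maximal response. No evidence bears on this result.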